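Title: From a chlorinated hydrazone to a ketone-derived analogue

A few compounds are considered here, and "the series" means these few. Any claim that something is new, unique, unknown or untested is made for them only; others in the source may bear on it.

For the measured compounds named here, compound 2 `CC1=CC[C@@H]([C@@](C)(O)CCCC(C)(C)NC(=S)N/N=C\c2ccccc2Cl)CC1` is the only member of this small set with an actual number: in a functional assay on K562 cells (Homo sapiens) for cytotoxicity, read by sulforhodamine B assay (a lower number here means that less compound is tolerated, a higher number that more compound is tolerated), compound 2 gives 8500 nM. Compound 1 `CC1=CC[C@@H]([C@@](C)(O)CCCC(C)(C)NC(=S)N/N=C\c2ccc(O)cc2)CC1` reaches only a limit of this assay, giving > 100000 nM. Going by the values given here, the single measured step, an at least 11-fold lower number from compound 1 to compound 2 (1.07 log units; beyond the scatter), starts from that limit of > 100000 nM in this assay, at which 1 of the 2 values shown sits, and is therefore itself only a lower bound on the change. Compound 3 `CC1=CC[C@@H]([C@@](C)(O)CCCC(C)(C)NC(=S)N/N=C(/C)c2ccccc2)CC1` differs from compound 2 by a group of 9 heavy atoms (8 carbon, 1 nitrogen; one six-membered aromatic ring of carbon only) in place of a group of 9 heavy atoms (7 carbon, 1 nitrogen, 1 chlorine; one six-membered aromatic ring of carbon only), on an amide-type nitrogen. Among the compounds with values here, no measured step covers a change of this kind: the step from compound 1 to compound 2 exchanges one aromatic group for another, whereas here the whole group on the amide-type nitrogen is replaced. Within the data shown here, with that large but differently placed step as the only guide, a step within the scatter or a moderate one upward is expected for compound 3. Compound 3 is estimated at 20000 nM, between 5000 nM and 100000 nM. The expected step is a 2.4-fold higher number from compound 2 to compound 3 (0.37 log units; beyond the scatter).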

Compound 3, concentration lethal to 50% of the cells: 1540 nM
Beside the measured number, compound 3's estimate is 13-fold (1.11 log units) above it; measured number outside the range, below it.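

In this assay, the change of group on the amide-type nitrogen gives a 5.5-fold lower number from compound 2 to compound 3 (0.74 log units; beyond the scatter), so this place still responds when one aromatic group carrying a carbon-based substitution replaces the chlorinated one. The entering group holds no chlorine, which shows that chlorine is not required for compound 3 to reach the lowest number of the three. Compared with the hydroxylated compound, the change gives an at least 64-fold lower number from compound 1 to compound 3 (1.81 log units; beyond the scatter), and this is only a lower bound because it starts from a limit: the limit of > 100000 nM in this assay, at which 1 of the 3 values shown sits.

The compounds shown do not separate how much of the step from the chlorinated group to the new one belongs to the lost chlorine and how much to the added carbon. They also leave open how the number would move with a methoxy group or a carboxylic acid on the aromatic ring.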